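A few compounds are considered here, and "the series" means these few. Any claim that something is new, unique, unknown or untested is made for them only; others in the source may bear on it.

Working notes on the series. In an ADME assay on HEK293 cells (Homo sapiens) for cytotoxicity, read by MTT assay, with a stated time of 48 h (on this read-out lower numbers stand for stronger inhibition and higher numbers for weaker inhibition), compound 1 `CCN(CC)CCn1c(N)c(-c2nc3ccccc3[nH]2)c2nc(C#N)c(C#N)nc21` gives 12200 nM and compound 2 `CN(C)CCCn1c(N)c(-c2nc3ccccc3[nH]2)c2nc(C#N)c(C#N)nc21` gives 8360 nM. The change between them is (dimethylamino)methyl in place of diethylamino on a saturated chain carbon, two bonds along the chain from an aromatic nitrogen and it made a 1.5-fold lower number from compound 1 to compound 2 (0.16 log units; within the scatter). Compound 3 `CCN(CC)CCCn1c(N)c(-c2nc3ccccc3n2C)c2nc(C#N)c(C#N)nc21` gives 7240 nM in this assay; set beside the numbers for compound 1 and compound 2 it lies within the scatter of both, so no order among the three is read. How the core of compound 3 differs from the core of compound 1 is not broken down here.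

Compound 4 `CN(C)CCCCn1c(N)c(-c2nc3ccccc3n2C)c2nc(C#N)c(C#N)nc21` has not been measured in this assay. It differs from compound 3 by (dimethylamino)methyl in place of diethylamino on a saturated chain carbon, three bonds along the chain from an aromatic nitrogen. This is the same kind of change as that seen between compound 1 and compound 2, not the same: there the place was two bonds along the chain from an aromatic nitrogen, here it is three. The step is expected to be a 1.2-fold lower number from compound 3 to compound 4 (0.08 log units; within the scatter), a step of about the size of the one earlier case, which resting on compound 1 and compound 2 gave a 1.5-fold lower number from compound 1 to compound 2 (0.16 log units; within the scatter). For compound 4 in this assay the estimate is 6000 nM, expected to lie between 3000 nM and 12000 nM.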

Compound 4, half-maximal inhibitory concentration: 3870 nM
The estimate for compound 4 lay 1.6-fold (0.19 log units) above the measured number, within the range that was stated.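

In this assay the change to (dimethylamino)methyl from diethylamino gives a 1.9-fold lower number from compound 3 to compound 4 (0.27 log units; within the scatter), here on a saturated chain carbon, three bonds along the chain from an aromatic nitrogen. This step and the earlier one each lie within the scatter, so neither pair shows that the change moves the number at all, and their agreement shows no effect that carries from core to core, only that no difference between the two cores appears for this change. The two cases read alike: the same change on two cores in this assay, a 1.5-fold lower number (0.16 log units; within the scatter) from compound 1 to compound 2 and a 1.9-fold lower number (0.27 log units; within the scatter) from compound 3 to compound 4, 1.3-fold (0.11 log units) apart, within the scatter of two such steps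

Read one bond further out, the second pair is 3-(diethylamino)propyl to 4-(dimethylamino)butyl, so the end amine and the chain change together, and the compounds shown leave open what each does alone, for instance dimethylamino and diethylamino compared on the same chain. Also open, going by these compounds, is how a cyclic amine such as morpholine or piperidine, or a carboxylic acid, at the chain end would read on either core.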